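Acylthiosemicarbazide series: expected cytotoxicity of compound 4

The source may hold more compounds than are shown below. What is called first, only, known or untested is meant among the compounds shown, and "the series" means these compounds.

Three compounds have numbers in a functional assay on GLC82 cells (Homo sapiens) for cytotoxicity, read by MTT assay, with a stated time of 72 h; a higher number here means a weaker inhibitor, a lower number a stronger inhibitor:

compound 1 `O=C(NC(=S)NNc1ncnc2ccccc12)c1ccccc1F`: 6460 nM
compound 2 `COc1cc2ncnc(NNC(=S)NC(=O)c3ccc(C)cc3)c2cc1OC`: 29900 nM
compound 3 `COc1cc2ncnc(NNC(=S)NC(=O)c3ccc(C(F)(F)F)cc3)c2cc1OC`: 16500 nM

Compound 1 stands lowest of the three numbers; the nearest, compound 3, lies beyond the scatter from it, and compound 2 further still. Within the data shown here, only one pair differs in a single place: a 1.8-fold lower number from compound 2 to compound 3 (0.26 log units; within the scatter), a trifluoromethyl in place of a methyl on an aromatic carbon, on the dimethoxy-bearing core that compound 1 lacks.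

Compound 4 `O=C(NC(=S)NNc1ncnc2ccccc12)c1cccc(Cl)c1` differs from compound 1 by 3-chlorophenyl in place of 2-fluorophenyl on a carbonyl carbon. Among the measured compounds shown here, no measured step exchanges one halogen for another on this ring, nor moves a substituent from one ring position to another, and no step at all has been measured on the unsubstituted core of compound 1. For the measured compounds named here, the one step that touches the acyl ring, from compound 2 to compound 3, stayed within the scatter. On that basis the step from compound 1 to compound 4 in this assay is expected to be small, with no direction beyond the scatter: a 1.1-fold lower number from compound 1 to compound 4 (0.03 log units; within the scatter). The estimate for compound 4 is 6000 nM, with a range from 2500 nM to 15000 nM, wide in view of the missing comparators.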

Compound 4, half-maximal inhibitory concentration: 3240 nM
Compound 4: the middle estimate sits 1.9-fold (0.27 log units) above what was measured, and the stated range covers the measured number.
By their numbers in this assay, from the lowest: compounds 4 and 1 (each within the scatter of the next); then compounds 3 and 2 (each within the scatter of the next).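

Working notes: on the core of compound 1, the aryl group on the carbonyl carbon now has a first step in this assay, where 3-chlorophenyl in place of 2-fluorophenyl gives a 2.0-fold lower number from compound 1 to compound 4 (0.30 log units; within the scatter); this single step exchanges both the halogen and its place on the ring. Together with a 1.8-fold lower number from compound 2 to compound 3 (0.26 log units; within the scatter), on the other core, there are now two steps at this aryl group, and both lie within the scatter, with no compound shown going against that. No evidence on the origin of either step is at hand.

Still open, going by these compounds, is whether a bare phenyl, a carboxylic acid or a dimethylamino group on this ring would carry the number beyond the scatter, and how the halogen exchange and the change of ring place each act alone. Among these compounds, no single-place step joins the core of compound 1 to the core of compound 2, so what the core alone contributes remains unread.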